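This account rests on a few compounds, and the source may have more. Where it says the series, first, only, none or still open, it means among the compounds named here.

Compound 1 `COc1cc(Cc2cnc(/N=C3\C(=O)N(CN4CCN(c5c(F)cc6c(=O)c(C(=O)O)cn(C7CC7)c6c5F)CC4C)c4ccc(Cl)cc43)nc2N)cc(OC)c1OC` gives "not determined" (no result reported) in an ADME assay on MT4 cells (Homo sapiens) for cytotoxicity, read by MTT assay, with a stated time of 5 days; a higher number here means that more compound is tolerated, a lower number that less compound is tolerated; the series gives no single number for it there, so its standing is unplaced. Among the measured compounds shown here, the two measured members are compound 2 `COc1cc(Cc2cnc(/N=C3\C(=O)N(CN4CCN(Cc5ccccc5)CC4)c4ccc(Cl)cc43)nc2N)cc(OC)c1OC` and compound 3 `COc1cc(Cc2cnc(/N=C3\C(=O)N(CN4CCN(c5ccc(F)cc5)CC4)c4ccc(Cl)cc43)nc2N)cc(OC)c1OC`, both carrying the shared core. In this assay compound 2 gives 36.1 ug/mL, and in this assay compound 3 gives 65.6 ug/mL. For the measured compounds named here, the one measured step, a 1.8-fold higher number from compound 2 to compound 3 (0.26 log units; within the scatter), exchanges a substituent on the amine nitrogen in a ring and leaves the numbers within the scatter of each other.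

Compound 4 `CCn1cc(C(=O)O)c(=O)c2cc(F)c(N3CCN(CN4C(=O)/C(=N\c5ncc(Cc6cc(OC)c(OC)c(OC)c6)c(N)n5)c5cc(Cl)ccc54)C(C)C3)c(F)c21` is the unmeasured partner of compound 1. The change is ethyl in place of cyclopropyl on an aromatic nitrogen. Going by the values given here, no measured step touches this aromatic nitrogen, and the one step in hand concerns a different site of the core, so it bears on the change only as a general sense of the spread among close analogues, which was small. No shift beyond the scatter in this assay is expected from this change alone.

Compound 4 is therefore estimated at 50 ug/mL in this assay, with a range from 15 ug/mL to 150 ug/mL, the band set by the values of compound 2 and compound 3.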

Compound 4, half-maximal cytotoxic concentration: 36.9 ug/mL
The estimate for compound 4 lay 1.4-fold (0.13 log units) above the measured number, within the range that was stated.
By their numbers in this assay, from the lowest: compounds 2, 4 and 3 (each within the scatter of the next).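

The pair compound 1 and compound 4 gives no readable step in this assay, where compound 4 gives 36.9 ug/mL and compound 1 gives "not determined" (no result reported) as its entry. As far as these compounds go, the effect of ethyl in place of cyclopropyl on the aromatic nitrogen therefore remains open. No supporting data bear on this result.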